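This account rests on a few compounds, and the source may have more. Where it says the series, first, only, none or still open, it means among the compounds named here.

Measured compounds:
compound 1 `Cc1cccc(Cc2cnc(CCc3ccc(-c4ccccc4C(=O)O)cc3)[nH]2)c1` gives 4310 nM in an in vitro functional assay on cells for agonist activity at Bombesin receptor subtype-3 (Homo sapiens), read by luminescence and calcium flux; on this read-out lower numbers stand for an effect already at smaller amounts and higher numbers for an effect only at larger amounts of compound;
compound 2 `CC(C)CCc1cnc(CCc2ccc(-c3ccccc3C(=O)O)cc2)[nH]1` gives 119 nM in this assay;
compound 3 `CC(C)(C)c1cnc(CCc2ccc(-c3ccccc3C(=O)O)cc2)[nH]1` gives 4330 nM in this assay.

Compound 3 has the highest number of the three, but its distance from compound 1 is only a 1.0-fold higher number from compound 1 to compound 3 (0.00 log units; within the scatter), which lies within the scatter, so the two are not distinguishable on this read-out. Among the measured compounds shown here, the only compound that stands apart is compound 2, with a 36-fold higher number from compound 2 to compound 3 (1.56 log units; beyond the scatter) separating it from compound 3 and a 36-fold lower number from compound 1 to compound 2 (1.56 log units; beyond the scatter) separating it from compound 1.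

Compound 4 `Cc1ccc(Cc2cnc(CCc3ccc(-c4ccccc4C(=O)O)cc3)[nH]2)cc1` has not yet been measured. The change from compound 3 is 4-methylbenzyl in place of tert-butyl on an aromatic carbon. For the measured compounds named here, the step that bears most closely on it is the one between compound 1 and compound 3, where a 3-methylbenzyl and a tert-butyl at the same ring carbon gave numbers within the scatter of each other. Going by the values given here, the 4-methylbenzyl of compound 4 is a close relative of that 3-methylbenzyl, so no step beyond the scatter is expected from compound 3 to compound 4, though the single example gives no certainty. The estimated step is a 1.1-fold lower number from compound 3 to compound 4 (0.03 log units; within the scatter). Compound 4 is therefore expected to give about 4000 nM in this assay, with a range from 1300 nM to 12000 nM.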

Compound 4, half-maximal effective concentration: 2660 nM
Beside the measured number, compound 4's estimate is 1.5-fold (0.18 log units) above it; low and high end bracket the measured number.
By their numbers in this assay, from the lowest: compound 2; then compounds 4, 1 and 3 (each within the scatter of the next).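

In this assay, exchanging the 3-methylbenzyl for the 4-methylbenzyl on this aromatic carbon gives no change beyond the scatter (a 1.6-fold lower number from compound 1 to compound 4 (0.21 log units; within the scatter)), and neither does exchanging tert-butyl for 4-methylbenzyl (a 1.6-fold lower number from compound 3 to compound 4 (0.21 log units; within the scatter)), so these three groups cannot be told apart on this read-out, although two carry a six-membered aromatic ring and tert-butyl has no ring. The isopentyl of compound 2 remains the exception, now set apart by a second benzyl group (a 22-fold higher number from compound 2 to compound 4 (1.35 log units; beyond the scatter)), so its separation no longer rests on compound 1 and compound 3 alone. Nothing given here accounts for why isopentyl stands apart from the other groups at this carbon.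

Among the compounds shown here, since isopentyl is the only group with a low number, it stays open whether an unbranched pentyl, a longer chain such as hexyl, or such a chain ending in a hydroxyl or an amine would give a number near that of compound 2. Also open, on these data alone, is whether an unsubstituted benzyl, or a benzyl bearing a methoxy group, would fall with compound 1 and compound 4.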